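This account rests on a few compounds, and the source may have more. Where it says the series, first, only, none or still open, it means among the compounds named here.

Among the measured compounds shown here, compound 3 `CC1(c2ccccc2)CC(=O)N(CC(=O)N2CCN(c3cccc(Cl)c3Cl)CC2)C1=O` is one of three compounds measured in a functional assay on the whole organism (strain CD-1) with Mus musculus as the target, with a stated time of 0.5 h; a lower number here means that less compound is needed, a higher number that more compound is needed for the effect; in that assay compound 3 gives 300 mg/kg. Compound 2 `CC1(c2ccccc2)CC(=O)N(CC(=O)N2CCN(c3ccc(Cl)cc3)CC2)C1=O` gives 300 mg/kg, so there is no change at the digits printed from compound 2 to compound 3 (within the scatter), and these two stand together as the highest of the three numbers. Compound 1 `CC1(c2ccccc2)CC(=O)N(CC(=O)N2CCN(c3ccccc3F)CC2)C1=O` gives 100 mg/kg, the lowest, with a 3.0-fold higher number from compound 1 to compound 2 (0.48 log units; beyond the scatter) and a 3.0-fold higher number from compound 1 to compound 3 (0.48 log units; beyond the scatter). Compound 4 `CC1(c2ccccc2)CC(=O)N(CC(=O)N2CCN(c3ncccn3)CC2)C1=O` alters the same position: pyrimidin-2-yl in place of 2,3-dichlorophenyl on an amine nitrogen in a ring. For the measured compounds named here, every measured step so far exchanges the ring attached to this nitrogen, and even the largest of them was modest, so only a modest shift at most is expected here, with no measured guide to its direction. Compound 4 is expected to give about 250 mg/kg, between 100 mg/kg and 1000 mg/kg. This corresponds to an expected 1.2-fold lower number from compound 3 to compound 4 (0.08 log units; within the scatter), within the scatter.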

Compound 4, minimum effective dose: "not active" (no number reported)
Compound 4 has no reported number here; no gap can be computed for the estimate.
By their numbers in this assay, from the lowest: compound 1; then compounds 2 and 3 (each within the scatter of the next).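

In this assay, among the compounds shown here, compound 4 is reported as not active, with no number, so no step from compound 3 to compound 4 can be read. No measured evidence bears on this result. The compounds shown leave open how far pyrimidin-2-yl on this nitrogen lies from the aryl rings in this read-out.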